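Methyl removal on two fused cores: one step measured

The source may report more compounds than this note shows. Statements on the series, on what has been measured and on what is new or still open speak of the compounds shown alone.

Compound 1 `COC(=O)c1sc2cc(C)ccc2c1Nc1cc(OC)c(OC)c(OC)c1` and compound 2 `COC(=O)c1sc2nc(C)ccc2c1Nc1cc(OC)c(OC)c(OC)c1` differ in their cores; that difference is not broken down here. In a functional assay on HeLa cells (Homo sapiens) for cytotoxicity, read by MTT assay, with a stated time of 72 h (a higher number here means a weaker inhibitor, a lower number a stronger inhibitor), compound 1 gives 0.31 nM and compound 2 gives 0.18 nM, the two within the scatter of each other. Compound 3 `COC(=O)c1sc2ncccc2c1Nc1cc(OC)c(OC)c(OC)c1` gives 342 nM in this assay, a step of a 1900-fold higher number from compound 2 to compound 3 (3.28 log units; beyond the scatter) for the change (hydrogen in place of methyl on an aromatic carbon).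

Compound 4 `COC(=O)c1sc2ccccc2c1Nc1cc(OC)c(OC)c(OC)c1` carries the same kind of change from compound 1, (hydrogen in place of methyl on an aromatic carbon), but the place differs: on a six-membered aromatic ring of carbon only rather than a ring with 1 nitrogen, next to the ring nitrogen. One precedent on another core gives limited footing, so a wide range is kept. Within the data shown here, compound 4 is expected to show a 970-fold higher number from compound 1 to compound 4 (2.99 log units; beyond the scatter) in this assay, resting on the single step of a 1900-fold higher number from compound 2 to compound 3 (3.28 log units; beyond the scatter). The estimate for compound 4 is 300 nM, expected between 10 nM and 6000 nM.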

Compound 4, half-maximal inhibitory concentration: 427 nM
Estimate against measurement, compound 4: 1.4-fold (0.15 log units) below, and the stated range covers the measured number.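

In this assay, hydrogen in place of methyl on an aromatic carbon gives a 1400-fold higher number from compound 1 to compound 4 (3.14 log units; beyond the scatter), and this step agrees with the one on the other core: the same change on two cores in this assay, a 1900-fold higher number (3.28 log units; beyond the scatter) from compound 2 to compound 3 and a 1400-fold higher number (3.14 log units; beyond the scatter) from compound 1 to compound 4, 1.4-fold (0.14 log units) apart, within the scatter of two such steps

On these two cores, the change therefore carries over with its size intact, and the methyl-bearing compounds hold the lower numbers in each pair. This rests on two pairs in one cell assay, so it does not show that the step would hold on a further core, nor does it explain why the methyl matters.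

The compounds shown leave open how other groups on that carbon would compare with methyl and hydrogen. An ethyl group, a longer chain, chlorine or an amine would test this.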